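The source may hold more compounds than are shown below. What is called first, only, known or untested is meant among the compounds shown, and "the series" means these compounds.

Measured compounds in a functional assay on HeLa cells (Homo sapiens) for inhibition, read by MTT assay, with a stated time of 48 h; a higher number here means a weaker inhibitor, a lower number a stronger inhibitor:
Compound 1 `COc1ccc2c(=O)c(/C=C/C(=O)Nc3ccc(Cl)cc3)coc2c1` — in this assay compound 1 gives > 100000 nM, which is a limit of the assay and not a number.
Compound 2 `Cc1ccccc1NC(=O)/C=C/c1coc2cc(O)ccc2c1=O` — in this assay compound 2 gives 8670 nM.
Compound 3 `COc1cccc(NC(=O)/C=C/c2coc3cc(OC)ccc3c2=O)c1` — in this assay compound 3 gives 19200 nM.

Compound 1 stands at the limit of > 100000 nM in this assay, at which 1 of the 3 values shown sits, and has no number of its own. Compound 4 `COc1ccc2c(=O)c(/C=C/C(=O)Nc3ccccc3C)coc2c1` differs from compound 1 in one place: 2-methylphenyl in place of 4-chlorophenyl on an amide-type nitrogen. Among the compounds with values here, the one measured step from compound 1, an at least 5.2-fold lower number from compound 1 to compound 3 (0.71 log units; beyond the scatter), shows that exchanging the 4-chlorophenyl moves the number off the limit. Compound 2, which carries the 2-methylphenyl on a core differing from that of compound 4, also gives a number well off the limit. A step in this assay toward a lower number, of at least the size seen for compound 3, is therefore expected: an at least 5.0-fold lower number from compound 1 to compound 4 (0.69 log units; beyond the scatter). Compound 4 is estimated at 20000 nM, within 5000 nM to 90000 nM.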

Compound 4, half-maximal inhibitory concentration: 7270 nM
Compound 4: the middle estimate sits 2.8-fold (0.44 log units) above what was measured, and the stated range covers the measured number.
By their numbers in this assay, from the lowest: compounds 4 and 2 (each within the scatter of the next); then compound 3. At a limit, above all of these: compound 1.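

In this assay, the 2-methylphenyl on the amide-type nitrogen goes further than the 3-methoxyphenyl, with a 2.6-fold lower number from compound 3 to compound 4 (0.42 log units; beyond the scatter), and its exchange for 4-chlorophenyl gives an at least 13-fold lower number from compound 1 to compound 4 (1.13 log units; beyond the scatter). With the 2-methylphenyl in place, methyl in place of hydrogen on the oxygen on the aromatic ring gives a 1.2-fold lower number from compound 2 to compound 4 (0.08 log units; within the scatter), so this exchange does not separate the two compounds. Compound 1 remains a limit and not a number: the limit of > 100000 nM in this assay, at which 1 of the 4 values shown sits.

On these data alone, whether a longer chain on that oxygen would hold the number in this range remains open. So does whether a 4-methylphenyl or a 2-aminophenyl on the amide-type nitrogen would do so.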